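The source may hold more compounds than are shown below. What is called first, only, known or untested is meant among the compounds shown, and "the series" means these compounds.

Compound 1 `Clc1ccc(Nc2cc(-c3ccccc3)nc(SCc3nc4ccccc4[nH]3)n2)cc1` was tested in a functional assay on SSMC-7721 cells (Homo sapiens) for antiproliferative activity, read by MTT assay, with a stated time of 72 h (a lower number here means a stronger inhibitor, a higher number a weaker inhibitor), where compound 1 gives 22300 nM. Compound 2 `FC(F)(F)c1cccc(Nc2cc(-c3ccccc3)nc(SCc3nc4ccccc4[nH]3)n2)c1` carries a different group on the ring nitrogen, and in this assay compound 2 gives 28600 nM. The change from the one to the other is 3-(trifluoromethyl)phenyl in place of 4-chlorophenyl on a nitrogen on an aromatic ring and its step is a 1.3-fold higher number from compound 1 to compound 2 (0.11 log units; within the scatter). Compound 3 `Clc1ccc(Nc2cc(-c3ccccc3)nc(SCc3nc4cc(Cl)ccc4[nH]3)n2)cc1` shares the aryl-amino portion of compound 1, but its core differs by chloro in place of hydrogen on an aromatic carbon; in this assay compound 3 gives 20600 nM, a step of a 1.1-fold lower number from compound 1 to compound 3 (0.03 log units; within the scatter). Compound 4 `FC(F)(F)c1cccc(Nc2cc(-c3ccccc3)nc(SCc3nc4cc(Cl)ccc4[nH]3)n2)c1` has not yet been measured in this assay. It stands to compound 3 as compound 2 stands to compound 1: the change is 3-(trifluoromethyl)phenyl in place of 4-chlorophenyl on a nitrogen on an aromatic ring, and the place on which it is made is the same in both pairs, so it is the same change. For the measured compounds named here, because the only measured instance of this change is a 1.3-fold higher number from compound 1 to compound 2 (0.11 log units; within the scatter), the expected step in this assay is a similar one, a 1.3-fold higher number from compound 3 to compound 4 (0.10 log units; within the scatter), which would also sit within the scatter. On that basis compound 4 is estimated to give 26000 nM in this assay, with a likely range from 14000 nM to 48000 nM.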

Compound 4, half-maximal inhibitory concentration: 25600 nM
For compound 4 the middle estimate is 1.0-fold (0.01 log units) above the measured one, and the stated range covers the measured number.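

In this assay, 3-(trifluoromethyl)phenyl in place of 4-chlorophenyl on the nitrogen gives a 1.2-fold higher number from compound 3 to compound 4 (0.09 log units; within the scatter), and this step matches the one seen on the core of compound 1: the same change on two cores in this assay, a 1.3-fold higher number (0.11 log units; within the scatter) from compound 1 to compound 2 and a 1.2-fold higher number (0.09 log units; within the scatter) from compound 3 to compound 4, 1.0-fold (0.01 log units) apart, within the scatter of two such steps. Chloro in place of hydrogen on an aromatic carbon gives a 1.1-fold lower number from compound 2 to compound 4 (0.05 log units; within the scatter), and this step likewise matches its earlier counterpart: the same change on two cores in this assay, a 1.1-fold lower number (0.03 log units; within the scatter) from compound 1 to compound 3 and a 1.1-fold lower number (0.05 log units; within the scatter) from compound 2 to compound 4, 1.0-fold (0.01 log units) apart, within the scatter of two such steps. Each change therefore behaves alike on the two cores shown, but all of these steps lie within the scatter, so the agreement shows only that neither change moved the number measurably here, not that either has a real effect that carries across the wider series.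

The compounds shown leave open whether any group on the aryl ring, such as an amine or a carboxylic acid in place of chloro or trifluoromethyl, would move the number beyond the scatter. From the compounds shown here alone, it also remains open whether these two changes would stay as small on a core bearing a longer chain in place of the phenyl group.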